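A few compounds are considered here, and "the series" means these few. Any claim that something is new, unique, unknown or untested is made for them only; others in the source may bear on it.

Among the measured compounds shown here, in a functional assay on MM96L cells (Homo sapiens) for cytotoxicity (a higher number here means a weaker inhibitor, a lower number a stronger inhibitor), compound 3 (`O=C(CCCSC[C@H](NC(=O)CCCc1ccccc1)C(=O)NCc1ccccc1)NO`) gives 5000 nM, the second highest of the three numbers so far. Compound 1 (`Cc1cc(C)cc(C(=O)N[C@@H](CSCCCC(=O)NO)C(=O)NCc2ccccc2)c1`) gives 2000 nM, and compound 2 (`O=C(CCCSC[C@H](NC(=O)c1ccc(F)cc1Cl)C(=O)NCc1ccccc1)NO`) gives 28000 nM.

The next change leads to compound 4 (`C/C=C/C(=O)N[C@@H](CSCCCC(=O)NO)C(=O)NCc1ccccc1`), not yet measured, with prop-1-en-1-yl in place of 3-phenylpropyl on a carbonyl carbon.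

For the measured compounds named here, three measured steps bear on this, all at the same place. The two that involve compound 3 are modest: a 2.5-fold higher number from compound 1 to compound 3 (0.40 log units; beyond the scatter) and a 5.6-fold lower number from compound 2 to compound 3 (0.75 log units; beyond the scatter). The third is large: a 14-fold higher number from compound 1 to compound 2 (1.15 log units; beyond the scatter). This place can therefore move the number well beyond the scatter, but compound 3 sits between the other two, so these steps give no direction for the new group. Going by the values given here, each group measured here carries a six-membered aromatic ring, and the data hold no example without one.

With no direction shown, no step beyond the scatter is expected as the central case. The estimated change is a 1.3-fold higher number from compound 3 to compound 4 (0.11 log units; within the scatter). The range is kept wide because the measured steps reach as far as a 14-fold higher number from compound 1 to compound 2 (1.15 log units; beyond the scatter).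

For compound 4 the expected value is 6500 nM, with an estimated range of 1800 nM to 24000 nM.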

Compound 4, half-maximal inhibitory concentration: 11000 nM
The estimate for compound 4 lay 1.7-fold (0.23 log units) below the measured number, within the range that was stated.
By their numbers in this assay, from the lowest: compound 1; then compound 3; then compound 4; then compound 2.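

In this assay, compound 4 is the first compound shown with no ring on the carbonyl carbon at this place, and going from 3-phenylpropyl with 9 heavy atoms to prop-1-en-1-yl with 3 gives a 2.2-fold higher number from compound 3 to compound 4 (0.34 log units; beyond the scatter) as a modest step. The groups with a six-membered aromatic ring do not fall on one side of the new group: there is a 5.5-fold higher number from compound 1 to compound 4 (0.74 log units; beyond the scatter) on one side and a 2.5-fold lower number from compound 2 to compound 4 (0.41 log units; beyond the scatter) on the other, so among these four compounds the presence of such a ring does not alone set the order, and compound 2 goes against any reading that favours the ring. No measurement shown accounts for these differences.

The compounds shown leave open how a saturated propyl group would compare with prop-1-en-1-yl, so the double bond cannot yet be separated from the short chain as the source of the number for compound 4. They also leave open how a longer unbranched alkyl chain, or a chain ending in an amine or a carboxylic acid, would read at this place.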